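Cyano for Acetyl on the Ethenyl Arm of Two Cores

A few compounds are considered here, and "the series" means these few. Any claim that something is new, unique, unknown or untested is made for them only; others in the source may bear on it.

Compound 2 `CC(=O)/C=C/n1cc(C)c(=O)[nH]c1=O` and compound 1 `Cc1cn(/C=C/C#N)c(=O)[nH]c1=O` share one core and differ by cyano in place of acetyl on a double-bonded chain carbon bound to a double-bonded chain carbon. In a functional assay on HeLa cells (Homo sapiens) for inhibition (on this read-out higher numbers stand for weaker inhibition and lower numbers for stronger inhibition), compound 2 gives only a limit, > 100000 nM. Compound 1 likewise gives only a limit in this assay, > 100000 nM. The step that the two limits leave unreadable from compound 2 to compound 1 is unreadable because both values sit at the limit of > 100000 nM in this assay, at which 2 of the 3 values shown sit. Compound 3 `CC(=O)/C=C/n1c(=O)ccn([C@H]2C[C@H](O)[C@@H](CO)O2)c1=O` carries a second core; how it differs from compound 2 is not broken down here. In this assay, within the data shown here, compound 3 gives 1500 nM, the only number among the three. Compound 4 `N#C/C=C/n1c(=O)ccn([C@H]2C[C@H](O)[C@@H](CO)O2)c1=O` differs from compound 3 by cyano in place of acetyl on a double-bonded chain carbon bound to a double-bonded chain carbon, the same change as that made from compound 2 to compound 1. The earlier step offers no size to carry over, so the expectation rests on compound 3 at 1500 nM and means an estimated step of a 1.3-fold higher number from compound 3 to compound 4 (0.12 log units; within the scatter) close to no change. Compound 4 is thus expected at 2000 nM, between 500 nM and 10000 nM.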

Compound 4, half-maximal inhibitory concentration: 100000 nM
The estimate for compound 4 lay 50-fold (1.70 log units) below the measured number; the measured number lies above the stated range.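

In this assay, cyano in place of acetyl on the core of compound 3 gives a 67-fold higher number from compound 3 to compound 4 (1.82 log units; beyond the scatter), a large loss of inhibition on that core. The same change on the core of compound 2 cannot be read, since both values there are limits of the assay and not numbers: the limit of > 100000 nM in this assay, at which 2 of the 4 values shown sit. The series therefore gives a size for the change on one core only, and it does not show whether that size carries over to the other core.

As far as these compounds go, it remains open how an ester or a carboxylic acid in place of acetyl, on a double-bonded chain carbon bound to a double-bonded chain carbon, would read on the core of compound 3. The same question stands for an amide there.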